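A few compounds are considered here, and "the series" means these few. Any claim that something is new, unique, unknown or untested is made for them only; others in the source may bear on it.

In a functional assay on HT-29 cells (Homo sapiens) for antiproliferative activity, read by MTT assay, with a stated time of 72 h (a higher number here means a weaker inhibitor, a lower number a stronger inhibitor), compound 1 `CCn1ccnc1-c1cc(OC)c(OC)c(OC)c1` gives > 100000 nM, a limit and not a number. Compound 2 `CCCn1ccnc1-c1cc(OC)c(OC)c(OC)c1` also gives only a limit, > 100000 nM. Compound 3 `COc1cc(-c2nccn2S(=O)(=O)c2ccccc2)cc(OC)c1OC` gives > 100000 nM, again a limit, so it has no exact place on the scale. Across the series the evidence is the limit of > 100000 nM in this assay, at which 3 of the 3 values shown sit. Among the measured compounds shown here, the only measured step is a step that the two limits leave unreadable from compound 1 to compound 2, which lies on a saturated chain and offers no size to carry over. Compound 4 `COc1cc(-c2nccn2S(=O)(=O)c2ccc(C)cc2)cc(OC)c1OC` differs from compound 3 by methyl in place of hydrogen on an aromatic carbon. The estimated step is a number no higher from compound 3 to compound 4 (the limit leaves the size open), with no change in either direction expected beyond the scatter. In this assay, compound 4 is estimated at 100000 nM, with an expected range from 30000 nM to 300000 nM.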

Compound 4, half-maximal inhibitory concentration: > 100000 nM
Compound 4: only a limit was reported; the forecaster's own chance of this, stated with the estimate: 75%; the middle value sits exactly at the limit.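

Compound 3 and compound 4 both give only a limit, so no step can be read between them. The compounds shown leave open what any of them would actually read in this assay, given this evidence: the limit of > 100000 nM in this assay, at which 4 of the 4 values shown sit.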